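From cyano to ethoxycarbonyl at the assay limit

The compounds below may be only part of what the source reports. "The series", "measured", "known", "first", "only" and "open" are said of these compounds alone.

Compound 1 `CCN(CC)c1ccc(-c2cccc(OC)c2)nn1`: > 25000 nM
Compound 2 `CCN(CC)c1ccc(-c2ccc(C#N)cc2)nn1`: > 25000 nM

Both entries come from a functional assay on HCT-116 cells (Homo sapiens) for antiproliferative activity, with a stated time of 48 h (a lower number here means a stronger inhibitor, a higher number a weaker inhibitor), and neither is an exact number. Compound 1 gives > 25000 nM, which is a limit. Compound 2 gives > 25000 nM, also a limit. Compound 2 therefore stands at the limit of > 25000 nM in this assay, at which 2 of the 2 values shown sit.

Compound 3 `CCOC(=O)c1ccc(-c2ccc(N(CC)CC)nn2)cc1` carries ethoxycarbonyl in place of cyano on an aromatic carbon, para to a large group: ethoxycarbonyl in place of cyano on an aromatic carbon. Among the measured compounds shown here, no measured step shows what a single change does here, so no step beyond the scatter is expected in this assay. The estimated step is a step that the limit leaves unreadable from compound 2 to compound 3. The estimate for compound 3 is 30000 nM, with an expected range from 15000 nM to 60000 nM.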

Compound 3, half-maximal inhibitory concentration: 500 nM
Compound 3: the middle estimate sits 60-fold (1.78 log units) above what was measured, outside the stated range (below it).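

In this assay, putting ethoxycarbonyl in place of cyano on an aromatic carbon, para to a large group, brings an at least 50-fold lower number from compound 2 to compound 3 (1.69 log units; beyond the scatter). This shows that the group at this position can decide whether the compounds give a readable number at all, which the earlier compounds could not show, as both of their values are limits: the limit of > 25000 nM in this assay, at which 2 of the 3 values shown sit.

Going by these compounds, whether a carboxylic acid or an amide at this position would give a lower or a higher number than ethoxycarbonyl stays open. Why ethoxycarbonyl gives this step also stays open.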